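This account rests on a few compounds, and the source may have more. Where it says the series, first, only, none or still open, it means among the compounds named here.

Compound 3 `CC(O)CCCC12CCC(c3nnc(-c4ccccc4C(F)(F)F)n3C)(CC1)CC2` stands highest of the three measured compounds in a functional assay on the whole organism (strain ICR) for inhibition, with Mus musculus as the target, with a stated time of 4 h, at a dose of 10 mg/kg by the oral route (on this read-out higher numbers stand for more inhibition at the one dose given (going by the name of the read-out) and lower numbers for less inhibition), where compound 3 gives 97%. Compound 1 `Cn1c(-c2ccccc2C(F)(F)F)nnc1C12CCC(CNS(C)(=O)=O)(CC1)CC2` gives 73% in this assay, and compound 2 `Cn1c(-c2ccccc2C(F)(F)F)nnc1C12CCC(COc3ccc(S(C)(=O)=O)cc3)(CC1)CC2` gives 79% in this assay. The step of a number 24 percentage points higher from compound 1 to compound 3 (beyond the scatter) and the step of a number 18 percentage points higher from compound 2 to compound 3 (beyond the scatter) both lie beyond the scatter, while the step of a number 6 percentage points higher from compound 1 to compound 2 (within the scatter) does not. Compound 4 `CCOCC12CCC(c3nnc(-c4ccccc4C(F)(F)F)n3C)(CC1)CC2` has not yet been measured. Its difference from compound 3 is ethoxy in place of 3-hydroxybutyl on a saturated chain carbon bound to a saturated ring carbon. The two steps that bear on this change are the ones ending at compound 3, both modest, both exchanges of the group on the same saturated chain carbon bound to a saturated ring carbon. Neither of them involves ethoxy, so the direction cannot be read off directly. The group that leaves is the one that gave the highest number, and the group that enters carries no hydrogen-bond donor. A modest fall rather than a gain is therefore expected for compound 4, as the step of a number 17 percentage points lower from compound 3 to compound 4 (beyond the scatter). Compound 4 is expected to give 80% in this assay, within a range from 55% to 97%.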

Compound 4, a percentage reported as inhibition, in the whole organism at one dose (the size of the read-out at that dose, not a potency): 44%
The estimate for compound 4 lay 36 percentage points above the measured number; the measured number lies below the stated range.
By their numbers in this assay, from the lowest: compound 4; then compounds 1 and 2 (each within the scatter of the next); then compound 3.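

In this assay, the group on this saturated chain carbon bound to a saturated ring carbon proves able to cost far more than the earlier exchanges suggested, with ethoxy for 3-hydroxybutyl giving a number 53 percentage points lower from compound 3 to compound 4 (beyond the scatter). The fall is not confined to the comparison with the top compound, since ethoxy also stands beyond the scatter under both other groups, with a number 35 percentage points lower from compound 2 to compound 4 (beyond the scatter) and a number 29 percentage points lower from compound 1 to compound 4 (beyond the scatter). Nothing here gives a reason for these falls.

The change from 3-hydroxybutyl to ethoxy alters the chain and removes the hydroxyl at once, so the compounds shown cannot tell which of the two matters. A plain butyl chain or a 3-methoxybutyl group in this place would separate them, and an amine on the same chain would test another kind of end group.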